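A few compounds are considered here, and "the series" means these few. Any claim that something is new, unique, unknown or untested is made for them only; others in the source may bear on it.

In a functional assay on U-87MG ATCC cells (Homo sapiens) for inhibition (on this read-out lower numbers stand for stronger inhibition and higher numbers for weaker inhibition), three amides built on a shared core have been measured, and they differ in the group on the amide carbonyl carbon. Compound 1 `COc1cc(/C=C/C(=O)c2cccc(NC(=O)c3cccs3)c2)ccc1O`, carrying thiophen-2-yl, gives 14.7 ug/mL. Compound 3 `COc1cc(/C=C/C(=O)c2cccc(NC(=O)c3ccc(Cl)c(Cl)c3)c2)ccc1O`, carrying 3,4-dichlorophenyl, gives 29.5 ug/mL, and the step between these two, a 2.0-fold higher number from compound 1 to compound 3 (0.30 log units; within the scatter), does not separate them. Compound 2 `COc1cc(/C=C/C(=O)c2cccc(NC(=O)c3cc(Cl)cc(Cl)c3)c2)ccc1O`, carrying 3,5-dichlorophenyl, reads > 50 ug/mL, which is a limit of the assay. Its steps are an at least 3.4-fold higher number from compound 1 to compound 2 (0.53 log units; beyond the scatter) and an at least 1.6-fold lower number from compound 2 to compound 3 (0.22 log units; that floor lies within the scatter), so only the first is clearly resolved.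

Compound 4 `CCOC(=O)C(=O)Nc1cccc(C(=O)/C=C/c2ccc(O)c(OC)c2)c1` has not yet been measured. Relative to compound 3, it has ethoxycarbonyl in place of 3,4-dichlorophenyl on a carbonyl carbon. For the measured compounds named here, none of the measured compounds has a group without a ring at this place, so the steps offer only indirect guidance. Swapping groups here has so far given steps from a 2.0-fold higher number from compound 1 to compound 3 (0.30 log units; within the scatter) to an at least 3.4-fold higher number from compound 1 to compound 2 (0.53 log units; beyond the scatter), and neither sets a direction for this change. No clear shift in this assay is therefore expected, and a reading at the limit remains possible. The expected step is a 1.2-fold lower number from compound 3 to compound 4 (0.07 log units; within the scatter). For compound 4 the estimated value is 25 ug/mL, with an expected range from 10 ug/mL to 50 ug/mL.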

Compound 4, half-maximal inhibitory concentration: > 50 ug/mL
Compound 4: a limit, no number (the forecaster's own chance of this, stated with the estimate: 20%); middle value at least 2.0-fold (0.30 log units) from the limit.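

Compound 4 is the only compound shown with a group without a ring at this place, and in this assay compound 4 reads > 50 ug/mL, which is a limit of the assay. Set against thiophen-2-yl, ethoxycarbonyl gives a resolved change, an at least 3.4-fold higher number from compound 1 to compound 4 (0.53 log units; beyond the scatter), whereas set against 3,4-dichlorophenyl it gives an at least 1.6-fold higher number from compound 3 to compound 4 (0.22 log units; that floor lies within the scatter), so only the comparison with compound 1 shows a clear shift. The ethoxycarbonyl group thus gives no reading below the limit, but having a ring is no guarantee of one either, since compound 2 also carries a ring, and the step from compound 2 to compound 4 cannot be read because both compounds end at the same limit: the limit of > 50 ug/mL in this assay, at which 2 of the 4 values shown sit.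

With only one group without a ring shown, the shift from compound 1 cannot be assigned to the missing ring rather than to the ethoxycarbonyl group itself. On these data alone, whether a simple longer alkyl chain, an amine or a carboxylic acid at this place would give a reading below the limit remains open.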